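Sulfone arylthio-propanamides: fluoro to trifluoromethyl step

This account rests on a few compounds, and the source may have more. Where it says the series, first, only, none or still open, it means among the compounds named here.

Measured so far in a functional assay on LNCaP cells (Homo sapiens) for antiproliferative activity, read by MTT assay, with a stated time of 96 h; a higher number here means a weaker inhibitor, a lower number a stronger inhibitor:
compound 1, `CC(CSc1cccc(OC(F)(F)F)c1)C(=O)Nc1ccc(C#N)c(C(F)(F)F)c1`, gives 115000 nM
compound 2, `CC(CSc1ccc(C(F)(F)F)cc1)C(=O)Nc1ccc([N+](=O)[O-])c(C(F)(F)F)c1`, gives 4410 nM
compound 3, `CC(CS(=O)(=O)c1ccc(F)cc1)C(=O)Nc1ccc(C#N)c(C(F)(F)F)c1`, gives 115000 nM

Compound 3 stands level with compound 1 at the digits shown; the two together have the highest numbers of the three. Compound 2 has by far the lowest number, and its gap to compound 3 lies beyond the scatter; compound 2 differs from compound 3 in more than one place, so its value alone does not say which part of the structure carries that gap.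

Compound 4, `CC(CS(=O)(=O)c1ccc(C(F)(F)F)cc1)C(=O)Nc1ccc(C#N)c(C(F)(F)F)c1`, has not been measured in this assay. It differs from compound 3 by trifluoromethyl in place of fluoro on an aromatic carbon, on an aromatic carbon of a six-membered aromatic ring of carbon only, para to a large group. Going by the values given here, no measured pair shows this change on its own. Compound 2 carries a trifluoromethyl on the corresponding ring and gives 4410 nM, but with a different linker and a different group on the other ring.

The step is expected to be small to moderate, towards a lower number, and the expectation is a 1.4-fold lower number from compound 3 to compound 4 (0.16 log units; within the scatter). Compound 4 is estimated at 80000 nM, with a range from 20000 nM to 150000 nM.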

Compound 4, half-maximal inhibitory concentration: 58000 nM
Compound 4: the middle estimate sits 1.4-fold (0.14 log units) above what was measured, and the stated range covers the measured number.
By their numbers in this assay, from the lowest: compound 2; then compounds 4, 1 and 3 (each within the scatter of the next).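

In this assay, the series now has its first step that changes one place only, trifluoromethyl in place of fluoro on an aromatic carbon, para to a large group, and it reads as a 2.0-fold lower number from compound 3 to compound 4 (0.30 log units; within the scatter) on the sulfone background. Going from 1 heavy atom to 4 heavy atoms at this place, with no hydrogen-bond donors or acceptors on either group, therefore does not take the number outside the scatter, so this change alone gives no measurable separation between the two compounds. No measurement on hand gives a reason for this step.

Compound 2 also carries a trifluoromethyl on the corresponding ring but differs from compound 4 in both the linker and the group on the other ring, so the shown compounds do not tell which of those two places goes with its value. Also open, from the compounds shown here alone, is whether a chloro group, a methoxy group or an amine at this same place on the sulfone, or a longer chain in the linker, would give a step beyond the scatter.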